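The source may report more compounds than this note shows. Statements on the series, on what has been measured and on what is new or still open speak of the compounds shown alone.

Of the compounds shown here, three sharing one core have been tested in a functional assay on FaDu cells (Homo sapiens) for cytotoxicity, read by MTT assay, with a stated time of 72 h; on this read-out lower numbers stand for higher toxicity in this test and higher numbers for lower toxicity in this test. Compound 1 `COc1ccc(NC(=O)C(=O)c2cn(C(C)C)c3cc(Cl)ccc23)cn1` gives 1770 nM in this assay. For compound 2 `COCCn1cc(C(=O)C(=O)Nc2ccc(OCC(=O)O)nc2)c2ccccc21` this assay reports only a limit, > 10000 nM. Compound 3 `COc1ccc(NC(=O)C(=O)c2cn(CC(C)(C)OC)c3ccccc23)cn1` likewise gives only a limit, > 10000 nM, so no number is known for it; it stands at the limit of > 10000 nM in this assay, at which 2 of the 3 values shown sit, together with compound 2, while compound 1 alone has a number. Compound 4 `CCC(C)n1cc(C(=O)C(=O)Nc2ccc(OC)nc2)c2ccccc21` has not yet been measured in this assay. It differs from compound 3 in one place: sec-butyl in place of 2-methoxy-2-methylpropyl on an aromatic nitrogen. Among the compounds with values here, no step between two measured compounds is recorded, so the size of this change can only be judged from the structures and the values at hand. Compound 3, carrying the 2-methoxy-2-methylpropyl group with its one hydrogen-bond acceptor, sits at the limit, and compound 4 replaces it with sec-butyl, which has none. The step from compound 3 to compound 4 is expected to run toward higher toxicity, roughly an at least 2.5-fold lower number from compound 3 to compound 4 (0.39 log units; beyond the scatter), although a result that again reaches only the limit cannot be ruled out. Compound 4 is therefore estimated at 4000 nM, within a range from 1000 nM to 15000 nM.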

Compound 4, concentration lethal to 50% of the cells: 68 nM
Compound 4: the middle estimate sits 59-fold (1.77 log units) above what was measured; the measured number lies below the stated range.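

Among the compounds shown, this is the first comparison of two compounds that differ in one place, and it shows that the group on the aromatic nitrogen can matter greatly in this assay: replacing 2-methoxy-2-methylpropyl with sec-butyl gives an at least 140-fold lower number from compound 3 to compound 4 (2.16 log units; beyond the scatter). That step is large and lies well beyond the usual scatter, so a small change in this one substituent is enough to move the result from a limit to a measured value showing much higher toxicity in this test. The starting point of the step is only a limit, not a number, so the true size of the change is not known, and the comparison begins at a value shared with another compound: the limit of > 10000 nM in this assay, at which 2 of the 4 values shown sit.

The change removes the ether oxygen and shortens the group at the same time, so the compounds shown cannot tell which of these two differences matters, or whether both do. They also leave open how a plain straight butyl chain, a longer alkyl chain or an amine on this same nitrogen would behave in this assay.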